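The compounds below may be only part of what the source reports. "The series", "measured", "known", "first", "only" and "open" are said of these compounds alone.

In an assay on isolated protein for binding affinity to vascular endothelial growth factor A, long form (Homo sapiens), read by surface plasmon resonance (a lower number here means tighter binding, a higher number weaker binding), compound 2, `CCN(CC(=O)NC[C@H]1O[C@H](OC)[C@@H](OS(=O)(=O)O)[C@@H](OS(=O)(=O)O)[C@@H]1OS(=O)(=O)O)C(=O)CCCc1ccccc1`, gives 81000 nM, the lowest of the two numbers recorded; the nearest is compound 1, `CCN(CC(=O)NC[C@H]1O[C@H](OC)[C@@H](OS(=O)(=O)O)[C@@H](OS(=O)(=O)O)[C@@H]1OS(=O)(=O)O)C(=O)CCCCCCCCCOS(=O)(=O)O`, which in this assay gives 545000 nM. Among the compounds with values here, the step of a 6.7-fold lower number from compound 1 to compound 2 (0.83 log units; beyond the scatter) is the only measured comparison at this position. Compound 3, `CCN(CC(=O)NC[C@H]1O[C@H](OC)[C@@H](OS(=O)(=O)O)[C@@H](OS(=O)(=O)O)[C@@H]1OS(=O)(=O)O)C(=O)CCCCC(=O)O`, carries a different change at the same position: carboxymethyl in place of phenyl on a saturated chain carbon, three bonds along the chain from a carbonyl carbon. This undoes the phenyl that accompanied the lower number in compound 2 and reinstates a polar, hydrogen-bonding tail, though a shorter one than in compound 1. Since a 6.7-fold lower number from compound 1 to compound 2 (0.83 log units; beyond the scatter) ran toward tighter binding when the polar chain gave way to phenyl, compound 3 is expected to move back toward a higher number, by a step of about a 3.7-fold higher number from compound 2 to compound 3 (0.57 log units; beyond the scatter). The estimate for compound 3 in this assay is 300000 nM, between 100000 nM and 900000 nM.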

Compound 3, dissociation constant: 104000 nM
For compound 3 the middle estimate is 2.9-fold (0.46 log units) above the measured one, within the range that was stated.
By their numbers in this assay, from the lowest: compounds 2 and 3 (each within the scatter of the next); then compound 1.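

In this assay, carboxymethyl in place of phenyl on a saturated chain carbon, three bonds along the chain from a carbonyl carbon, gives a 1.3-fold higher number from compound 2 to compound 3 (0.11 log units; within the scatter), so at this position a tail without the phenyl ring can match the value of compound 2. Compound 1 remains apart from both, with a 5.2-fold lower number from compound 1 to compound 3 (0.72 log units; beyond the scatter), so the difference first seen with phenyl also appears with a tail ending in a carboxylic acid, and the 6-(sulfooxy)hexyl tail of compound 1 is the one that stands alone. Nothing here gives a measured reason for either step.

The compounds shown leave open whether the sulfate ester at the end of the tail or the length of the tail sets compound 1 apart. A shorter chain ending in a sulfate ester, a longer chain ending in a carboxylic acid, or a chain ending in an amine could separate these possibilities.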